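Diaminoquinoxaline series: aryl ether to aryl thioether swap

A few compounds are considered here, and "the series" means these few. Any claim that something is new, unique, unknown or untested is made for them only; others in the source may bear on it.

Measured compounds:
compound 1 `CCOC(=O)[C@H](CCC(=O)O)NC(=O)c1ccc(Sc2nc3cc(N)cc(N)c3nc2-c2ccccc2)cc1`, < 100000 nM
compound 2 `Nc1cc(N)c2nc(-c3ccccc3)c(Oc3ccc(F)cc3)nc2c1`, 34700 nM
compound 3 `COc1ccc(CNc2nc3cc(N)cc(N)c3nc2-c2ccccc2)cc1OC`, 34700 nM

In a functional assay on 786-0 cells (Homo sapiens) for inhibition, read by sulforhodamine B assay, with a stated time of 48 h (a lower number here means a stronger inhibitor of growth, a higher number a weaker inhibitor of growth), compound 2 gives 34700 nM. Compound 3 sits level with it in this assay at 34700 nM, the two values not separated beyond the scatter, so no order between them is claimed. Among the measured compounds shown here, compound 1 carries the related sulfanyl linkage with a longer ester-bearing tail; its result in this assay is a limit of the assay and not a number, (the limit of < 100000 nM in this assay, at which 1 of the 3 values shown sits), so it gives no step to build on.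

Compound 4 `COc1ccc(Sc2nc3cc(N)cc(N)c3nc2-c2ccccc2)cc1` is the next member to be measured. It differs from compound 2 by (4-methoxyphenyl)sulfanyl in place of 4-fluorophenoxy on an aromatic carbon. For the measured compounds named here, no pair of measured compounds differing in a single place is available to calibrate this change, and compound 1 supplies only a limit, so the step is expected to be small, in no fixed direction, and within the scatter. The estimate for compound 4 in this assay is 30000 nM, with a range of 8000 nM to 100000 nM, which would mean an expected step of a 1.2-fold lower number from compound 2 to compound 4 (0.06 log units; within the scatter).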

Compound 4, concentration for total growth inhibition: 30200 nM
Estimate against measurement, compound 4: 1.0-fold (0.00 log units) below; measured number inside the range.
By their numbers in this assay, from the lowest: compounds 4, 2 and 3 (each within the scatter of the next).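

Replacing 4-fluorophenoxy with (4-methoxyphenyl)sulfanyl on the aromatic carbon next to the ring nitrogen gives a 1.1-fold lower number from compound 2 to compound 4 (0.06 log units; within the scatter) in this assay, so this change does not separate the two compounds. Compound 4 supplies a numeric value for a sulfur-linked aryl group at this carbon, to set with the oxygen-linked group of compound 2 and the nitrogen-linked group of compound 3, and the three values lie each within the scatter of the next. Compound 1, the other sulfur-linked member, remains a limit and not a number, and it gives no comparison with compound 4: the limit of < 100000 nM in this assay, at which 1 of the 4 values shown sits.

The step changes the linking atom and the ring substituent together, so their separate contributions cannot be read. From the compounds shown here alone, a 4-fluorophenylsulfanyl or 4-methoxyphenoxy group would divide the two, and whether any group at this carbon gives a step beyond the scatter remains open.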